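This account rests on a few compounds, and the source may have more. Where it says the series, first, only, none or still open, it means among the compounds named here.

Values in a functional assay on A549 cells (Homo sapiens) for cytotoxicity, read by MTT assay, with a stated time of 72 h; a higher number here means a weaker inhibitor, a lower number a stronger inhibitor:
- compound 1 `CC[S+]([O-])CCCCN=C=S`: 10200 nM
- compound 2 `CC(C)[S+]([O-])CCCCN=C=S`: 10400 nM
- compound 3 `CC(C)C[S+]([O-])CCCCN=C=S`: not yet measured

Compound 2 stands at 10400 nM, within the scatter of compound 1. The next change is isobutyl in place of isopropyl on a sulfur. Among the compounds with values here, one measured step bears on it: a 1.0-fold higher number from compound 1 to compound 2 (0.01 log units; within the scatter), also a change in the group on the sulfur. Within the data shown here, with a single small step as the only guide, no step beyond the scatter is expected in this assay. The expected step is a 1.0-fold lower number from compound 2 to compound 3 (0.02 log units; within the scatter). Compound 3 is estimated at 10000 nM, with an expected range of 5000 nM to 20000 nM.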

Compound 3, half-maximal inhibitory concentration: 9090 nM
Estimate against measurement, compound 3: 1.1-fold (0.04 log units) above; the range from low to high includes it.
By their numbers in this assay, from the lowest: compounds 3, 1 and 2 (each within the scatter of the next).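

In this assay, isobutyl in place of isopropyl on the sulfur gives a 1.1-fold lower number from compound 2 to compound 3 (0.06 log units; within the scatter), and the comparison with the shared core's smaller group gives a 1.1-fold lower number from compound 1 to compound 3 (0.05 log units; within the scatter). The series now holds isobutyl, with its four carbons, on this sulfur without a step beyond the scatter, so the flat reading extends past the first pair. No measured evidence accounts for this flat reading.

Open, going by these compounds, is whether a benzyl group, an amine or a carboxylic acid on this sulfur would give a step beyond the scatter. On these data alone, a much longer chain there is equally open.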